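This account rests on a few compounds, and the source may have more. Where it says the series, first, only, none or still open, it means among the compounds named here.

Working notes on a set of three acids sharing one core, each carrying a benzophenone-type carbonyl and an ether-linked aromatic group, tested in an assay for displacement of a labelled ligand from 3-oxo-5-alpha-steroid 4-dehydrogenase 1 (Rattus norvegicus), at pH 6.6, tested at 10 uM; a higher number here means more inhibition at the concentration tested (going by the name of the read-out), a lower number less inhibition.

Compound 1 `O=C(O)c1ccc(C(=O)c2ccc(Oc3ccccc3)cc2)cc1` gives 53% in this assay. Compound 3 `O=C(O)c1ccc(C(=O)c2ccc(OCc3cc(C(F)(F)F)ccc3C(F)(F)F)cc2)cc1` gives 69%, and compound 2 `O=C(O)c1ccc(C(=O)c2cccc(OCc3ccccc3)c2)cc1` gives 35%. Compound 1 thus stands second of the three numbers: compound 3 sits higher by a gap beyond the scatter, and compound 2 sits lower by a gap that is also beyond the scatter. No two of these compounds differ in only one place, so no measured step is available for any pair.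

The compound not yet measured is compound 4 `O=C(O)c1ccc(C(=O)c2ccc(OCc3ccccc3)cc2)cc1`. Against compound 1 its change is benzyl in place of phenyl on an oxygen on an aromatic ring, which read one bond further out is phenoxy to benzyloxy. Going by the values given here, there is no measured step to lean on. Compound 3 also carries a benzyloxy group and gives 69%; compound 2 carries a benzyloxy group as well and gives 35%; these two numbers bracket the value of compound 1 on both sides. The step from compound 1 to compound 4 is therefore expected to be small, within the scatter, as a number 2 percentage points higher from compound 1 to compound 4 (within the scatter). Compound 4 is estimated at 55%, in a range from 35% to 75%.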

Compound 4, a percentage reported as inhibition, at one concentration (the size of the read-out at that concentration, not a potency): 64%
Compound 4: the middle estimate sits 9 percentage points below what was measured, within the range that was stated.
By their numbers in this assay, from the lowest: compound 2; then compound 1; then compounds 4 and 3 (each within the scatter of the next).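

In this assay, going by these compounds alone, this gives the first readable step: a number 11 percentage points higher from compound 1 to compound 4 (beyond the scatter), with benzyl in place of phenyl on an oxygen on an aromatic ring. The step is modest but beyond the scatter, so at this position a change from six to seven heavy atoms, with the same aromatic ring and no change in the counts of hydrogen-bond donors, acceptors or net charge, is enough to shift the inhibition read-out upward. Nothing available bears on why the benzyloxy group reads higher than the phenoxy group here.

This single step cannot show whether the rise continues with a longer chain on the same oxygen, such as phenylethyl, or whether it depends on the chain itself rather than on the particular benzyl group. Within the data shown here, it also leaves open how an amine or a methoxy group on the benzyl ring would read on the core of compound 4, since no measured step so far isolates a substituent on that ring.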